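Methylsulfanyl in place of cyano on compound 2

The source may hold more compounds than are shown below. What is called first, only, known or untested is meant among the compounds shown, and "the series" means these compounds.

Within the data shown here, in an in vitro ADME assay on microsomes from liver (Homo sapiens) for metabolic stability, with a stated time of 15 min (on this read-out lower numbers stand for slow clearance and higher numbers for fast clearance), compound 2 (`COCc1cc(OC)c(-c2cccc3c(N(CC4CCOCC4)CC4CC4)c(C#N)nn23)c(OC)c1`) stands at 1100 mL.min-1.g-1 and has the highest number of the three compounds measured so far. Compound 3 (`CCc1nn2c(-c3c(C)cc(C)cc3OC)cccc2c1N(CC1CCOCC1)CC1CC1`) gives 450 mL.min-1.g-1 and compound 1 (`COCc1cc(OC)c(-c2cccc3c(N(CC4CCOCC4)CC4CC4)c(C)nn23)c(OC)c1`) gives 110 mL.min-1.g-1 at the low end of the set.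

Compound 4 (`COCc1cc(OC)c(-c2cccc3c(N(CC4CCOCC4)CC4CC4)c(SC)nn23)c(OC)c1`) differs from compound 2 in one place, on an aromatic carbon of the five-membered aromatic ring with 2 nitrogen, where methylsulfanyl stands in place of cyano (methylsulfanyl in place of cyano on an aromatic carbon). Among the measured compounds shown here, only one measured step bears on this carbon. Cyano in place of methyl gave a 10-fold higher number from compound 1 to compound 2 (1.00 log units; beyond the scatter) and so shows that the group here can move the number well beyond the scatter. For the measured compounds named here, compound 3 differs from the others in more than one place and offers no clean step. Going by the values given here, no measurement yet shows what methylsulfanyl itself does, so the expectation rests on that single step and remains loose. Removing the cyano is expected to give back part of that rise, though not all of it. The expected change is a 2.2-fold lower number from compound 2 to compound 4 (0.34 log units; beyond the scatter) on this read-out. The estimated value for compound 4 is 500 mL.min-1.g-1 with an expected range of 180 mL.min-1.g-1 to 1300 mL.min-1.g-1 in this assay as it stands.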

Compound 4, intrinsic clearance in microsomes: 340 mL.min-1.g-1
The estimate for compound 4 lay 1.5-fold (0.17 log units) above the measured number; the range from low to high includes it.
By their numbers in this assay, from the lowest: compound 1; then compounds 4 and 3 (each within the scatter of the next); then compound 2.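

In this assay, methylsulfanyl in place of cyano on this aromatic carbon gives a 3.2-fold lower number from compound 2 to compound 4 (0.51 log units; beyond the scatter), while methylsulfanyl in place of methyl gives a 3.1-fold higher number from compound 1 to compound 4 (0.49 log units; beyond the scatter). The earlier compounds shown here offered only the contrast between methyl and cyano, whereas this carbon now carries three groups on an otherwise unchanged core, and compound 4 falls between the other two, with both steps beyond the scatter. The result therefore shows that the read-out at this position is not simply a choice between two extremes, although no measurement here accounts for the order of the three groups.

The compounds shown leave open how a longer sulfur-linked chain such as ethylsulfanyl, an oxygen-linked group such as methoxy, or an amine would compare on this same carbon. They also leave open whether the same order of methyl, methylsulfanyl and cyano would hold with the different aromatic group carried by compound 3, since no matched set on that background is available here.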